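The source may report more compounds than this note shows. Statements on the series, on what has been measured and on what is new or still open speak of the compounds shown alone.

Measured compounds:
- compound 1 `Cc1ccc(NC(=O)Nc2cccc(CNc3nccnc3Cl)c2)cc1C`: 9870 nM
- compound 2 `Cc1ccc(NC(=O)Nc2cccc(CNc3nccnc3Cl)c2)cc1`: 11900 nM
- compound 3 `O=C(Nc1cccc(CNc2nccnc2Cl)c1)Nc1ccccc1F`: 6440 nM

All three compounds share one core and differ only in the aryl group attached to an amide-type nitrogen. In a functional assay on MGC-803 cells (Homo sapiens) for antiproliferative activity, read by MTT assay, with a stated time of 48 h (on this read-out lower numbers stand for stronger inhibition and higher numbers for weaker inhibition), compound 3 gives the lowest number of the three, but its separations from the others, a 1.5-fold lower number from compound 1 to compound 3 (0.19 log units; within the scatter) and a 1.8-fold lower number from compound 2 to compound 3 (0.27 log units; within the scatter), both lie within the scatter, so none of the three can be called stronger than another. Compound 4 `O=C(Nc1ccc(Cl)cc1)Nc1cccc(CNc2nccnc2Cl)c1` is not yet measured. Its structure differs from compound 3 in one place: 4-chlorophenyl in place of 2-fluorophenyl on an amide-type nitrogen. Among the compounds with values here, the steps that bear on this change are the two earlier aryl swaps on the same nitrogen, a 1.5-fold lower number from compound 1 to compound 3 (0.19 log units; within the scatter) and a 1.8-fold lower number from compound 2 to compound 3 (0.27 log units; within the scatter), together with a 1.2-fold higher number from compound 1 to compound 2 (0.08 log units; within the scatter), all of them within the scatter. A swap of one aryl group for another at this position has therefore produced no step beyond the scatter so far, and no larger step is expected here. The expected step for compound 4 is a 1.0-fold higher number from compound 3 to compound 4 (0.00 log units; within the scatter). Compound 4 is estimated at 6500 nM, within a range of 2500 nM to 17000 nM.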

Compound 4, half-maximal inhibitory concentration: 4980 nM
Compound 4: the middle estimate sits 1.3-fold (0.12 log units) above what was measured; measured number inside the range.
By their numbers in this assay, from the lowest: compounds 4, 3, 1 and 2 (each within the scatter of the next, the first and the last beyond it).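

In this assay, the change from 2-fluorophenyl to 4-chlorophenyl on the amide-type nitrogen stays small (a 1.3-fold lower number from compound 3 to compound 4 (0.11 log units; within the scatter)), and the change from 3,4-dimethylphenyl to 4-chlorophenyl also stays within the scatter (a 2.0-fold lower number from compound 1 to compound 4 (0.30 log units; within the scatter)). The new information is that this position can give a step beyond the scatter: chloro in place of methyl on an aromatic carbon gives a modest one (a 2.4-fold lower number from compound 2 to compound 4 (0.38 log units; beyond the scatter)), the first in this set. No measurement shown offers a reason for these steps.

From the compounds shown here alone, it remains open whether that step belongs to chlorine itself or to its place on the ring, a question that 4-fluorophenyl or 2-chlorophenyl on the same nitrogen would address. Going by these compounds, how the number responds to a quite different group at this nitrogen, such as cyclohexyl or a phenyl bearing a carboxylic acid, also remains unknown.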